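This account rests on a few compounds, and the source may have more. Where it says the series, first, only, none or still open, it means among the compounds named here.

Compound 1 `Cc1cc2c(cc1Cc1ccc(C(=O)NCc3ccc(CN)cc3)o1)C(C)(C)CCC2(C)C` gives 140 nM in an assay on isolated protein for binding affinity to Gonadotropin-releasing hormone receptor (Homo sapiens); a lower number here means a stronger inhibitor, a higher number a weaker inhibitor. Compound 2 `Cc1cc2c(cc1Cc1ccc(C(=O)NCC3CCC(CN)CC3)o1)C(C)(C)CCC2(C)C` gives 42 nM in this assay.

Within the data shown here, compound 2 stands at the lowest of the two numbers measured so far; its nearest neighbour is compound 1, and the step of a 3.3-fold lower number from compound 1 to compound 2 (0.52 log units; beyond the scatter) separates them, a modest change that lies beyond the scatter. Compound 3 `Cc1cc2c(cc1Cc1ccc(C(=O)NCC3CCCC(CN)C3)o1)C(C)(C)CCC2(C)C` has not yet been measured. It has the same atoms as compound 2, joined differently: 3-(aminomethyl)cyclohexyl in place of 4-(aminomethyl)cyclohexyl on a saturated chain carbon bound to an amide-type nitrogen. Among the measured compounds shown here, the only measured step exchanged 4-(aminomethyl)phenyl for 4-(aminomethyl)cyclohexyl, a ring that compound 3 keeps; it does not test where the aminomethyl group sits on that ring, so it bears only indirectly on the present change. With the saturated ring retained and only the placement of the aminomethyl group moved, a step in this assay that stays close to the scatter, leaning slightly towards a higher number, is expected. Compound 3 is therefore estimated at 80 nM in this assay, within 25 nM to 300 nM, which means an expected step of a 1.9-fold higher number from compound 2 to compound 3 (0.28 log units; within the scatter).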

Compound 3, inhibition constant: 174 nM
Estimate against measurement, compound 3: 2.2-fold (0.34 log units) below; measured number inside the range.
By their numbers in this assay, from the lowest: compound 2; then compounds 1 and 3 (each within the scatter of the next).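

Where the aminomethyl group sits on the saturated ring matters in this assay: moving it gives a 4.1-fold higher number from compound 2 to compound 3 (0.62 log units; beyond the scatter), although the atoms stay the same and only their connection changes. The other comparison gives a 1.2-fold higher number from compound 1 to compound 3 (0.09 log units; within the scatter), so compound 3 cannot be told apart from compound 1, and the saturated ring brings no measurable difference from the 4-(aminomethyl)phenyl group when it carries the 3-(aminomethyl)cyclohexyl arrangement; the advantage seen for compound 2 therefore depends on the 4-(aminomethyl)cyclohexyl group, not on the presence of a saturated ring alone. No accompanying data bear on the reason for this difference.

The compounds shown leave open whether moving the aminomethyl group in the same way on the phenyl ring would also change the number in this assay. They also leave open whether the amine has to stay on a one-carbon link, since neither a longer chain such as aminoethyl nor a carboxylic acid in place of the aminomethyl group appears among them.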